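The source may hold more compounds than are shown below. What is called first, only, known or untested is meant among the compounds shown, and "the series" means these compounds.

Measured compounds:
Compound 1, `N#CSCN1C(=O)c2ccccc2C1=O`: in a functional assay on PC-3 cells (Homo sapiens) for cytotoxicity, read by MTT assay, with a stated time of 72 h (a lower number here means a stronger inhibitor of growth, a higher number a weaker inhibitor of growth), compound 1 gives > 100000 nM, which is a limit of the assay.
Compound 2, `N#C[Se]CN1C(=O)c2ccccc2C1=O`: compound 2 gives 32100 nM.
Compound 3, `Cc1noc(C)c1CSC#N`: compound 3 gives 13800 nM.

The change from compound 1 to compound 2 is a group of 3 heavy atoms (1 carbon, 1 nitrogen, 1 selenium; no ring) in place of a group of 3 heavy atoms (1 carbon, 1 nitrogen, 1 sulfur; no ring), on a saturated chain carbon bound to an amide-type nitrogen in a ring; it made an at least 3.1-fold lower number from compound 1 to compound 2 (0.49 log units; beyond the scatter), with the size bounded only by the limit of > 100000 nM in this assay, at which 1 of the 3 values shown sits. The core of compound 3 is not the core of compound 1, and the difference between the two cores is not broken down here.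

Compound 4, `Cc1noc(C)c1C[Se]C#N`, is not yet measured. It differs from compound 3 by a group of 3 heavy atoms (1 carbon, 1 nitrogen, 1 selenium; no ring) in place of a group of 3 heavy atoms (1 carbon, 1 nitrogen, 1 sulfur; no ring), on a saturated chain carbon bound to an aromatic carbon, the same kind of change as from compound 1 to compound 2, though the place differs: there the carbon is bound to an amide-type nitrogen in a ring, here to an aromatic carbon. A step of similar size is expected, a 3.1-fold lower number from compound 3 to compound 4 (0.49 log units; beyond the scatter), resting on compound 2 at 32100 nM. Compound 4 is estimated at 4500 nM, between 1500 nM and 14000 nM.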

Compound 4, concentration for total growth inhibition: 10300 nM
The estimate for compound 4 lay 2.3-fold (0.36 log units) below the measured number; the range from low to high includes it.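

On the core of compound 3, putting the selenium-bearing group in place of cyanosulfanyl gives a 1.3-fold lower number from compound 3 to compound 4 (0.13 log units; within the scatter) in this assay, so no step beyond the scatter appears on this core. The change therefore is not shown to carry over at the size seen on the core of compound 1, yet a real difference between the two cores is not shown either: the same change on two cores in this assay, an at least 3.1-fold lower number (0.49 log units; beyond the scatter) from compound 1 to compound 2 and a 1.3-fold lower number (0.13 log units; within the scatter) from compound 3 to compound 4; the limit leaves it open whether they differ. The step on the core of compound 1 has no fixed size, since compound 1 stands at a limit and not a number: the limit of > 100000 nM in this assay, at which 1 of the 4 values shown sits.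

Two matched pairs on two cores cannot define a trend across the series. As far as these compounds go, whether the step holds with a longer chain in place of the saturated chain carbon, or on a core bearing an amine or a carboxylic acid, stays open.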